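The source may report more compounds than this note shows. Statements on the series, on what has been measured and on what is new or still open speak of the compounds shown alone.

Working notes on the series. All compounds share one core and differ only in the group on the six-membered aromatic ring of carbon only. Compound 1 `CC(C)(C)c1ccc(C(=O)NN2C(=O)NC3(CC3(C)C)C2=O)cc1` gives 30 mg/kg in a functional assay on the whole organism (Hindlimb) for inhibition, with Mus musculus as the target, with a stated time of 0.5 h; a higher number here means that more compound is needed for the effect, a lower number that less compound is needed. Compound 2 `CC1(C)CC12NC(=O)N(NC(=O)c1ccc(Cl)cc1)C2=O` gives 100 mg/kg in this assay. Compound 3 `CC1(C)CC12NC(=O)N(NC(=O)c1ccc(Br)cc1)C2=O` gives 300 mg/kg in this assay, the highest of the three numbers, with compound 2 nearest and compound 1 furthest, both gaps beyond the scatter. The measured steps are a 3.3-fold higher number from compound 1 to compound 2 (0.52 log units; beyond the scatter), a 10-fold higher number from compound 1 to compound 3 (1.00 log units; beyond the scatter) and a 3.0-fold higher number from compound 2 to compound 3 (0.48 log units; beyond the scatter). Each change made so far has raised the number.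

Compound 4 `CC1(C)CC12NC(=O)N(NC(=O)c1ccc(F)cc1)C2=O` differs from compound 3 by fluoro in place of bromo on an aromatic carbon. The step that bears most directly on it is a 3.0-fold higher number from compound 2 to compound 3 (0.48 log units; beyond the scatter), a modest change between two halogens. Also relevant is a 3.3-fold higher number from compound 1 to compound 2 (0.52 log units; beyond the scatter), which shows that the halogen-bearing compounds have needed more compound than the tert-butyl compound. For the measured compounds named here, no step involving fluoro has been measured, so the three numbers do not show whether the chloro-to-bromo direction continues or reverses. A step from bromo to fluoro is expected to run opposite to the chloro-to-bromo step, as a 3.0-fold lower number from compound 3 to compound 4 (0.48 log units; beyond the scatter), with wide uncertainty. Compound 4 is expected at 100 mg/kg, with a range from 30 mg/kg to 300 mg/kg.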

Compound 4, minimum effective dose: 100 mg/kg
Estimate against measurement, compound 4: no gap at the digits printed; measured number inside the range.
By their numbers in this assay, from the lowest: compound 1; then compounds 2 and 4 (each within the scatter of the next); then compound 3.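

In this assay the change from bromo to fluoro gives a 3.0-fold lower number from compound 3 to compound 4 (0.48 log units; beyond the scatter) and the change from chloro to fluoro gives no change at the digits printed from compound 2 to compound 4 (within the scatter) at this place on the six-membered aromatic ring of carbon only, so the number does not climb steadily through the halogens: compound 2 and compound 4 cannot be told apart, and only compound 3 stands apart from them. Replacing tert-butyl with fluoro gives a 3.3-fold higher number from compound 1 to compound 4 (0.52 log units; beyond the scatter) and thus matches the earlier tert-butyl steps, with all three halogen compounds needing more compound than compound 1 and none of them going against this. Nothing on hand gives a reason for compound 3 standing apart from the other two halogen compounds, or for the gap to compound 1.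

The compounds shown leave open whether a group other than a halogen or tert-butyl at this place, such as a methoxy group, a nitrile or an amine, would give a lower number than compound 1. They also leave open how a plain hydrogen or a longer chain would read here.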